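Cytotoxicity of an amide series: a naphthyl replacement

This account rests on a few compounds, and the source may have more. Where it says the series, first, only, none or still open, it means among the compounds named here.

Measured compounds in a functional assay on C8166 cells (Homo sapiens) for cytotoxicity, read by MTT assay; on this read-out higher numbers stand for lower toxicity in this test and lower numbers for higher toxicity in this test:
Compound 1 `Cc1cc(S(N)(=O)=O)ccc1NC(=O)COc1ccc(Cl)cc1NC(=O)c1cccc(C(F)(F)F)c1`: 124000 nM
Compound 2 `Cc1cc(C)cc(C(=O)Nc2cc(Cl)ccc2OCC(=O)Nc2ccc(S(N)(=O)=O)cc2C)c1`: 36500 nM
Compound 3 `Cc1cc(S(N)(=O)=O)ccc1NC(=O)COc1ccc(Cl)cc1NC(=O)c1ccc(Cl)cc1Cl`: 61100 nM

Among these three, compound 1 has the highest number, so it is the least toxic of the set in this assay. The nearest to it is compound 3, the step being a 2.0-fold lower number from compound 1 to compound 3 (0.31 log units; beyond the scatter); the furthest is compound 2, with a 3.4-fold lower number from compound 1 to compound 2 (0.53 log units; beyond the scatter). Between compound 2 and compound 3 the difference is a 1.7-fold higher number from compound 2 to compound 3 (0.22 log units; within the scatter).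

Compound 4 `Cc1cc(S(N)(=O)=O)ccc1NC(=O)COc1ccc(Cl)cc1NC(=O)c1cccc2ccccc12` is not yet measured. It differs from compound 1 in one place: naphthalen-1-yl in place of 3-(trifluoromethyl)phenyl on a carbonyl carbon. The group sits on a carbonyl carbon whose other neighbour is an amide-type nitrogen, so the change, cut one bond further out, reads as (3-(trifluoromethyl)phenyl)carbonyl to (naphthalen-1-yl)carbonyl.

The two measured steps that alter this same group both lowered the number modestly, as a 3.4-fold lower number from compound 1 to compound 2 (0.53 log units; beyond the scatter) and a 2.0-fold lower number from compound 1 to compound 3 (0.31 log units; beyond the scatter) show. A third such change in the same place is therefore expected to lower the number again, by a modest amount. For compound 4 the estimated step is a 2.1-fold lower number from compound 1 to compound 4 (0.32 log units; beyond the scatter). Compound 4 is expected to give 60000 nM, within a range from 25000 nM to 150000 nM.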

Compound 4, half-maximal cytotoxic concentration: > 381000 nM
Compound 4 was reported as a limit; the forecaster's own chance of this, stated with the estimate: 10%; at least 6.3-fold (0.80 log units) between middle value and limit.
By their numbers in this assay, from the lowest: compounds 2 and 3 (each within the scatter of the next); then compound 1. At a limit, above all of these: compound 4.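

In this assay, compound 4 is reported only as a limit, > 381000 nM. Measured against the other compounds, that limit gives an at least 3.0-fold higher number from compound 1 to compound 4 (0.48 log units; beyond the scatter), an at least 6.2-fold higher number from compound 3 to compound 4 (0.79 log units; beyond the scatter) and an at least 10-fold higher number from compound 2 to compound 4 (1.01 log units; beyond the scatter), so all three steps run toward lower toxicity in this test. The earlier compounds shown here showed only replacements of 3-(trifluoromethyl)phenyl that lowered the number, whereas this position also allows a change in the opposite direction, and the leaving and entering groups have the same number of heavy atoms and no hydrogen-bond donors or acceptors, so those counts do not separate naphthalen-1-yl from 3-(trifluoromethyl)phenyl here.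

As far as these compounds go, with only a limit for compound 4, the full size of each of these steps remains open. The compounds shown also leave open whether it is the second aromatic ring or the way it is attached that goes with the higher number, a question that naphthalen-2-yl or a plain phenyl group on the same carbonyl carbon would help to answer.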